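Swapping Acetyl for Dimethylamino on a Weakly Active Pyrazole

A few compounds are considered here, and "the series" means these few. Any claim that something is new, unique, unknown or untested is made for them only; others in the source may bear on it.

Of the compounds shown here, three sharing one core have been tested in a functional assay on Malme-3M cells (Homo sapiens) for cytotoxicity, read by sulforhodamine B assay, with a stated time of 48 h, tested at 100 nM; a higher number here means a weaker effect of the compound at the concentration tested, a lower number a stronger effect. Compound 1 `COc1cc(C)cc(-c2c(-c3ccnc(-c4ccc(C(C)=O)cc4)c3)cnn2CC#N)c1` gives 97% in this assay, the highest of the three numbers, meaning the weakest effect. Compound 2 `COc1cc(C)cc(-c2nn(CC#N)cc2-c2ccc(-c3cccc(C(C)=O)c3)nc2)c1` gives 66% in this assay, a number well below that of compound 1, and compound 3 `COc1cc(C)cc(-c2nn(CC#N)cc2-c2ccnc(-c3ccc(N(C)C)cc3)c2)c1` gives 46% in this assay, further below still. Both gaps lie beyond the usual scatter, so compound 1 stands clearly apart as the least effective of the three.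

Compound 4 `COc1cc(C)cc(-c2c(-c3ccnc(-c4ccc(N(C)C)cc4)c3)cnn2CC#N)c1` is not yet measured. It differs from compound 1 in one place: dimethylamino in place of acetyl on an aromatic carbon. Compound 3 already carries a dimethylamino group, though on a differently joined core, and its value in this assay is far lower than that of compound 1. On that ground the step from compound 1 to compound 4 is expected to lower the number beyond the scatter, estimated as a number 35 percentage points lower from compound 1 to compound 4 (beyond the scatter). Compound 4 is therefore expected to give about 62% in this assay, within a range of 38% to 90%.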

Compound 4, a percentage reported as activity, at one concentration (the size of the read-out at that concentration, not a potency): 49%
Beside the measured number, compound 4's estimate is 13 percentage points above it; low and high end bracket the measured number.
By their numbers in this assay, from the lowest: compounds 3 and 4 (each within the scatter of the next); then compound 2; then compound 1.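

The change from 4-acetylphenyl to 4-(dimethylamino)phenyl gives a number 48 percentage points lower from compound 1 to compound 4 (beyond the scatter) in this assay. Among the compounds shown here, this is the first comparison of the two groups on one unchanged core. The earlier compounds shown here differ from each other in more than one place and could not give this comparison. The new result shows that the group at this position of the aromatic ring can by itself change the read-out, even though acetyl and dimethylamino have equal counts of heavy atoms and hydrogen-bond acceptors. No measurement at hand explains why this swap has such an effect.

From the compounds shown here alone, it remains open whether a plain amine, a morpholine ring or a carboxylic acid at this place would shift the number further or reverse the change. Since the read-out comes from one concentration, the size of the effect there also says nothing about potency.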